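A few compounds are considered here, and "the series" means these few. Any claim that something is new, unique, unknown or untested is made for them only; others in the source may bear on it.

Measured in a functional assay on the whole organism with Mus musculus as the target; a lower number here means that less compound is needed, a higher number that more compound is needed for the effect:
- Compound 1 `CN(C)C(=O)CCC(=O)c1cccc(C(F)(F)F)c1`: > 37.5 mg/kg, a limit
- Compound 2 `CC(C)CNC(=O)CCC(=O)c1cccc(C(F)(F)F)c1`: > 200 mg/kg, a limit
- Compound 3 `O=C(CCC(=O)c1cccc(C(F)(F)F)c1)NC1CCCCC1`: > 200 mg/kg, a limit

Compound 3 has no exact number, only a limit, (the limit of > 200 mg/kg in this assay, at which 2 of the 3 values shown sit).

Compound 4 `CN1CCN(C(=O)CCC(=O)c2cccc(C(F)(F)F)c2)CC1` puts 4-methylpiperazin-1-yl in place of cyclohexylamino on a carbonyl carbon.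

Three measured steps change this same group: a step that the two limits leave unreadable from compound 1 to compound 2, a step that the two limits leave unreadable from compound 1 to compound 3 and a step that the two limits leave unreadable from compound 2 to compound 3. None of them gives a size or a direction to carry over, so the expectation here is loose. The expected step, with its direction uncertain, is an at least 1.3-fold lower number from compound 3 to compound 4 (0.12 log units; that floor lies within the scatter). Compound 4 is estimated at 150 mg/kg, within a range of 40 mg/kg to 400 mg/kg, and a limit rather than a number is also likely.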

Compound 4, dose for half-maximal effect: > 37.5 mg/kg
Compound 4 was reported as a limit; the forecaster's own chance of this, stated with the estimate: 65%; the middle value is on the limit's open side.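

In this assay, within the data shown here, compound 4 is reported only as a limit, as are compounds 1, 2 and 3, so no step among them can be read. The compounds shown leave open what dose any of them needs, and whether the group on the carbonyl carbon changes it.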